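Methoxy on the Urea Ring: Expected Cytotoxicity of Compound 4

The source may report more compounds than this note shows. Statements on the series, on what has been measured and on what is new or still open speak of the compounds shown alone.

Compound 2 `O=C(N/N=C1\C(=O)Nc2ccccc21)Nc1ccccc1` carries a phenylurea on a shared core. In an ADME assay on RD cells (Homo sapiens) for cytotoxicity (on this read-out lower numbers stand for higher toxicity in this test and higher numbers for lower toxicity in this test), compound 2 reaches only the limit of > 25000 nM, not a measured number. Compound 3 `Cc1ccc(NC(=O)N/N=C2\C(=O)Nc3ccccc32)cc1` likewise gives only the limit of > 25000 nM in this assay. Compound 1 `O=C1Nc2ccccc2/C1=N/NC(=S)Nc1ccc(Cl)cc1`, with a thiourea and a chloro group, also stops at the limit of > 25000 nM in this assay. Because (the limit of > 25000 nM in this assay, at which 3 of the 3 values shown sit), the step that the two limits leave unreadable from compound 2 to compound 3 cannot be read. Compound 4 `COc1cccc(NC(=O)N/N=C2\C(=O)Nc3ccccc32)c1` differs from compound 2 by methoxy in place of hydrogen on an aromatic carbon. Within the data shown here, the one comparable step, methyl for hydrogen, was unreadable, so nothing measured shows how this change acts. Compound 4 is therefore expected to sit near the same limit, and the step that the limit leaves unreadable from compound 2 to compound 4 is expected to stay within the scatter. The estimate for compound 4 is 30000 nM, between 20000 nM and 60000 nM.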

Compound 4, half-maximal cytotoxic concentration: > 25000 nM
Compound 4 ended at the assay's limit (the forecaster's own chance of this, stated with the estimate: 85%); the middle value is on the limit's open side.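

Among these compounds, no step from compound 2 to compound 4 can be read, because both stop at a limit rather than a number: the limit of > 25000 nM in this assay, at which 4 of the 4 values shown sit. The compounds shown leave open whether methoxy in place of hydrogen changes cytotoxicity at all.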